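Swapping the aryl alkyl for methoxy in the amide series

The compounds below may be only part of what the source reports. "The series", "measured", "known", "first", "only" and "open" are said of these compounds alone.

Three amides sharing one core have been measured in a functional assay on A549 cells (Homo sapiens) for inhibition, read by MTT assay, with a stated time of 72 h; a lower number here means a stronger inhibitor, a higher number a weaker inhibitor. Compound 1 `O=C(Nc1ccccc1)C1CCN(C/C=C/c2ccccc2)CC1`, with an unsubstituted phenyl on the amide, gives 69700 nM. Compound 2 `CCc1ccc(NC(=O)C2CCN(C/C=C/c3ccccc3)CC2)cc1` gives 19600 nM, and compound 3 `CC(C)c1ccc(NC(=O)C2CCN(C/C=C/c3ccccc3)CC2)cc1` gives 9430 nM, the lowest of the three numbers and the most potent of the set.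

Going by the values given here, the steps so far all concern adding carbon to the aryl ring: a 3.6-fold lower number from compound 1 to compound 2 (0.55 log units; beyond the scatter), a 7.4-fold lower number from compound 1 to compound 3 (0.87 log units; beyond the scatter), and a 2.1-fold lower number from compound 2 to compound 3 (0.32 log units; beyond the scatter). Each addition lowered the number, and the larger group gave the larger drop.

Among the compounds with values here, compound 4 `COc1ccc(NC(=O)C2CCN(C/C=C/c3ccccc3)CC2)cc1` is the next case. methoxy in place of isopropyl on an aromatic carbon The entering group is smaller than the one leaving and brings an acceptor; no measured step covers such a swap, so the alkyl series is the only guide. Because the smaller ethyl in compound 2 sat at 19600 nM, a group of two heavy atoms is expected to land near that level or weaker, giving an expected 2.7-fold higher number from compound 3 to compound 4 (0.42 log units; beyond the scatter). Compound 4 is therefore estimated at 25000 nM, within 8000 nM to 70000 nM.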

Compound 4, half-maximal inhibitory concentration: 83800 nM
Estimate against measurement, compound 4: 3.4-fold (0.53 log units) below; measured number outside the range, above it.
By their numbers in this assay, from the lowest: compound 3; then compound 2; then compounds 1 and 4 (each within the scatter of the next).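

At this place, on an aromatic carbon para to a large group, the lowering of the number seen with ethyl and isopropyl does not carry over to methoxy, which gives an 8.9-fold higher number from compound 3 to compound 4 (0.95 log units; beyond the scatter) and a 4.3-fold higher number from compound 2 to compound 4 (0.63 log units; beyond the scatter) in the two comparisons with the alkyl groups. Set against the unsubstituted phenyl, methoxy gives a 1.2-fold higher number from compound 1 to compound 4 (0.08 log units; within the scatter) so putting a group at this place does not in itself lower the number, and among the listed compounds only ethyl and isopropyl do so. Nothing measured here accounts for the gap between methoxy and the alkyl groups.

As far as these compounds go, whether ethoxy or isopropoxy, which keep the oxygen and add carbon, would follow the alkyl groups or stay with methoxy remains open. So does the outcome with tert-butyl or an amine at the same place.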